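A few compounds are considered here, and "the series" means these few. Any claim that something is new, unique, unknown or untested is made for them only; others in the source may bear on it.

In an ADME assay on MT4 cells (Homo sapiens) for cytotoxicity, read by MTT assay, with a stated time of 4 days (a higher number here means that more compound is tolerated, a lower number that less compound is tolerated), compound 3 `COc1cccc(-c2oc3ccc(NC(C)=O)cc3c(=O)c2O)c1` gives 33300 nM, the lower of the two actual numbers. Compound 2 `COc1ccccc1-c1oc2ccc(NC(C)=O)cc2c(=O)c1O` gives 385000 nM. Compound 1 `COc1cccc(-c2cc(=O)c3cc(NC(C)=O)ccc3o2)c1` gives > 404000 nM, which is a limit of the assay. Unmeasured compound 4 `CC(=O)Nc1ccc2oc(-c3cccc(F)c3)c(O)c(=O)c2c1` carries fluoro in place of methoxy on an aromatic carbon, meta to a large group: fluoro in place of methoxy on an aromatic carbon. Two large measured steps bear on this only indirectly. Hydroxy in place of hydrogen gave an at least 12-fold lower number from compound 1 to compound 3 (1.08 log units; beyond the scatter), a size resting on a limit (the limit of > 404000 nM in this assay, at which 1 of the 3 values shown sits). 3-Methoxyphenyl in place of 2-methoxyphenyl gave a 12-fold lower number from compound 2 to compound 3 (1.06 log units; beyond the scatter). Compound 4 keeps that hydroxy and that place on the ring, and neither step replaces the methoxy itself. The expected step, leaning to a higher number and much smaller than either, is a 1.8-fold higher number from compound 3 to compound 4 (0.26 log units; within the scatter). For compound 4 the estimate is 60000 nM, with an expected range of 15000 nM to 200000 nM.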

Compound 4, half-maximal cytotoxic concentration: 26500 nM
Compound 4: middle estimate off by 2.3-fold (0.35 log units), on the high side, and the stated range covers the measured number.
By their numbers in this assay, from the lowest: compounds 4 and 3 (each within the scatter of the next); then compound 2. At a limit, above all of these: compound 1.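

In this assay, the methoxy is not required at this place on the ring: fluoro replaces it with a 1.3-fold lower number from compound 3 to compound 4 (0.10 log units; within the scatter), which stays within the scatter. The large gap to the 2-methoxyphenyl compound also survives the change, as a 15-fold lower number from compound 2 to compound 4 (1.16 log units; beyond the scatter). The low number of compound 3 therefore recurs with a group that has no oxygen, so for these two compounds it does not rest on the methoxy itself.

From the compounds shown here alone, whether an amine or a longer chain at this place would shift the number remains open. Nothing shown gives a reason for either step.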